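From piperazin-1-yl to methoxy on a shared core

The source may report more compounds than this note shows. Statements on the series, on what has been measured and on what is new or still open speak of the compounds shown alone.

Among the measured compounds shown here, in a functional assay on HepG2 cells (Homo sapiens) for inhibition, read by MTT assay, with a stated time of 72 h (on this read-out lower numbers stand for stronger inhibition and higher numbers for weaker inhibition), compound 3 (`CC(C)(C)n1cc2c(n1)C(=O)CC1(CCN(C(=O)c3cc(N4CCNCC4)nc4ccccc34)CC1)O2`) gives 8570 nM, the highest of the three numbers measured so far. Compound 1 (`COc1ccc(-c2cc(C(=O)N3CCC4(CC3)CC(=O)c3nn(C(C)(C)C)cc3O4)c3ccccc3n2)cc1`) gives 2780 nM, and compound 2 (`CN(C)c1ccc(-c2cc(C(=O)N3CCC4(CC3)CC(=O)c3nn(C(C)(C)C)cc3O4)c3ccccc3n2)cc1`) gives 1730 nM. These two lie within the scatter of each other, with a 1.6-fold lower number from compound 1 to compound 2 (0.21 log units; within the scatter).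

Compound 4 (`COc1cc(C(=O)N2CCC3(CC2)CC(=O)c2nn(C(C)(C)C)cc2O3)c2ccccc2n1`) has not yet been measured. It differs from compound 3 by methoxy in place of piperazin-1-yl on an aromatic carbon, with methoxy in place of piperazin-1-yl on an aromatic carbon.

Two measured steps change the group on that same carbon: a 3.1-fold higher number from compound 1 to compound 3 (0.49 log units; beyond the scatter) and a 5.0-fold higher number from compound 2 to compound 3 (0.69 log units; beyond the scatter). Both are modest and beyond the scatter, and both end at piperazin-1-yl with the higher number. For the measured compounds named here, no measured compound has methoxy itself on that carbon, so these steps are only an indirect guide. Going by the values given here, on the evidence of compound 1 and compound 2, a modest move to a lower number is expected, probably no larger than those steps.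

The expected change is a 1.9-fold lower number from compound 3 to compound 4 (0.28 log units; within the scatter). For compound 4, the estimated value is 4500 nM, with an expected range from 1800 nM to 11000 nM.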

Compound 4, half-maximal inhibitory concentration: > 10000 nM
Compound 4: a limit, no number (the forecaster's own chance of this, stated with the estimate: 10%); middle value at least 2.2-fold (0.34 log units) from the limit.
By their numbers in this assay, from the lowest: compounds 2 and 1 (each within the scatter of the next); then compound 3. At a limit, above all of these: compound 4.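

In this assay compound 4 reads only as a limit of the assay, not as a number: the limit of > 10000 nM in this assay, at which 1 of the 4 values shown sits.

The 4-methoxyphenyl and 4-(dimethylamino)phenyl groups on this aromatic carbon go with lower numbers than methoxy does, a gap seen as an at least 3.5-fold higher number from compound 1 to compound 4 (0.55 log units; beyond the scatter) and as an at least 5.7-fold higher number from compound 2 to compound 4 (0.76 log units; beyond the scatter) and beyond the scatter in both cases. The third step is an at least 1.1-fold higher number from compound 3 to compound 4 (0.06 log units; that floor lies within the scatter) and its floor lies within the scatter, so the swap of piperazin-1-yl for methoxy gave no sign of the lower number that compounds 1 and 2 had pointed to.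

On these data alone, how far the true value of compound 4 lies past its limit stays open, and with it the full size of that swap. Also open, as far as these compounds go, is whether an unsubstituted phenyl or a dimethylamino group set directly on this carbon would go with numbers like those of compound 1 and compound 2.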